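Swapping the Benzyl Halogen on a Weak Antiproliferative Scaffold

A few compounds are considered here, and "the series" means these few. Any claim that something is new, unique, unknown or untested is made for them only; others in the source may bear on it.

Going by the values given here, compound 2 `O=C1NC(=O)/C(=C/c2cn(Cc3ccccc3Br)c3ccccc23)N1` is one of two compounds measured in a functional assay on A549 cells (Homo sapiens) for antiproliferative activity, read by trypan blue exclusion, with a stated time of 24 h; a lower number here means a stronger inhibitor, a higher number a weaker inhibitor. In this assay compound 2 gives 39500 nM. Its companion, compound 1 `COC(=O)c1ccc(Cn2cc(/C=C3\NC(=O)NC3=O)c3ccccc32)cc1`, reaches only a limit of the assay in this assay, reported as > 40000 nM. Among the two values shown, compound 2 therefore stands as the sole numerical result, with the other lying at the limit of > 40000 nM in this assay, at which 1 of the 2 values shown sits.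

Compound 3 `O=C1NC(=O)/C(=C/c2cn(Cc3ccc(F)cc3)c3ccccc23)N1` has not yet been measured in this assay. It differs from compound 2 in a single place: 4-fluorophenyl in place of 2-bromophenyl on a saturated chain carbon bound to an aromatic nitrogen. Among the compounds with values here, no step between measured compounds is available that would show how this kind of exchange shifts the read-out, so the expectation rests on the weak result of compound 2 alone.

Given that compound 2 sits at 39500 nM, compound 3 is expected to remain a weak inhibitor, with an estimated step of a 1.0-fold higher number from compound 2 to compound 3 (0.01 log units; within the scatter) that stays within the usual scatter rather than marking a real change. The estimated half-maximal inhibitory concentration for compound 3 is 40000 nM, with a plausible range from 15000 nM to 100000 nM.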

Compound 3, half-maximal inhibitory concentration: 27800 nM
The estimate for compound 3 lay 1.4-fold (0.16 log units) above the measured number; measured number inside the range.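

In this assay, going by these compounds alone, the first step that can be read at this place, on a saturated chain carbon bound to an aromatic nitrogen, is a 1.4-fold lower number from compound 2 to compound 3 (0.15 log units; within the scatter), so replacing 2-bromobenzyl with 4-fluorobenzyl produces no real change and leaves the read-out in the same weak range. The second step, for fluoro in place of methoxycarbonyl on an aromatic carbon, is an at least 1.4-fold lower number from compound 1 to compound 3 (0.15 log units; that floor lies within the scatter), and it gives only a floor that does not establish a real difference between the two compounds. Compound 1 carries a limit of the assay rather than a number: the limit of > 40000 nM in this assay, at which 1 of the 3 values shown sits.

Within the data shown here, the one step at this place changes both the halogen and its place on the ring, so 4-bromobenzyl or 2-fluorobenzyl would be needed to tell these two changes apart. Going by these compounds, it also remains open whether an amine or a carboxylic acid on the benzyl ring, or a longer chain in place of the benzyl link, would move the shared core out of this weak range, since all three compounds shown sit close together at the top of what the assay can report.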